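A few compounds are considered here, and "the series" means these few. Any claim that something is new, unique, unknown or untested is made for them only; others in the source may bear on it.

Working notes on the series. Compound 1 `COc1cc(C)nc2n/c(=N/C(=O)c3c(-c4ccc(Cl)cc4Cl)noc3C)sn12` is assessed in a functional assay on the whole organism for inhibition, with Brassica napus as the target, with a stated time of 72 h, tested at 10 mg/L; on this read-out lower numbers stand for less inhibition of growth and higher numbers for more inhibition of growth at the one concentration tested; here compound 1 gives 26.4%. Among the three measured numbers this is the second highest. Compound 2 `COc1cc(Cl)nc(NC(=S)NC(=O)c2c(-c3ccc(Cl)cc3Cl)noc2C)n1` gives 30.7%, a number within the scatter of compound 1. Compound 3 `Cc1cc(Cl)nc(NC(=S)NC(=O)c2c(-c3ccc(Cl)cc3Cl)noc2C)n1` gives 8.36%, a number below compound 1 beyond the scatter. Compound 4 `COc1cc(OC)n2s/c(=N\C(=O)c3c(-c4ccc(Cl)cc4Cl)noc3C)nc2n1` is not yet measured; it differs from compound 1 by methoxy in place of methyl on an aromatic carbon. Among the measured compounds shown here, one measured step bears on this change, in the reverse direction: a number 22.3 percentage points lower from compound 2 to compound 3 (beyond the scatter). For the measured compounds named here, compound 2 and compound 3 share a core different from that of compound 1 and compound 4, so the size of that step need not carry over in full, but it is the only guide available and its direction is clear. The change from methyl to methoxy is therefore expected to raise growth inhibition in this assay, by a step of about a number 13.6 percentage points higher from compound 1 to compound 4 (beyond the scatter). For compound 4 the expected value is 40%, with an estimated range from 25% to 58%.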

Compound 4, percent growth inhibition at one concentration: 49.3%
Compound 4: the middle estimate sits 9.3 percentage points below what was measured, and the stated range covers the measured number.
By their numbers in this assay, from the lowest: compound 3; then compounds 1 and 2 (each within the scatter of the next); then compound 4.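

In this assay, methoxy in place of methyl on an aromatic carbon next to the ring nitrogen gives a number 22.9 percentage points higher from compound 1 to compound 4 (beyond the scatter). Among the compounds shown here, the change was previously seen on only one core, and the result now shows it on the fused core of compound 1 as well. Neither pair goes against the trend, and the size of the step is closely matched across the two cores: the same change on two cores in this assay, a number 22.3 percentage points lower (beyond the scatter) from compound 2 to compound 3 and a number 22.9 percentage points lower (beyond the scatter) from compound 4 to compound 1, 0.6 percentage points apart, within the scatter of two such steps

The compounds shown carry only methyl or methoxy at this position, so it remains open how an ethoxy group or an amine would read there, and whether the oxygen itself matters. All values come from a single concentration, leaving open how compound 4 and compound 1 would compare across a range of concentrations.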